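Replacing the (4-methoxyphenyl)amino bridge with 3-fluorophenyl

The source may report more compounds than this note shows. Statements on the series, on what has been measured and on what is new or still open speak of the compounds shown alone.

Compound 1 has the structure `C=C[C@@](C)(/C=C/c1ccc(Nc2ccc(OC)cc2)cc1)CCC=C(C)C`. In a functional assay on SEM cells (Homo sapiens) for cytotoxicity, with a stated time of 72 h (on this read-out higher numbers stand for an effect only at larger amounts of compound and lower numbers for an effect already at smaller amounts), compound 1 gives > 36600 nM, which is a limit of the assay rather than a measured number. Compound 2, with structure `C=C[C@@](C)(/C=C/c1ccc(Nc2ccc(OC)c(OC)c2)cc1)CCC=C(C)C`, carries a methoxy in place of hydrogen on an aromatic carbon, and in this assay compound 2 gives > 36600 nM, again only a limit. Compound 3, with structure `C=C[C@@](C)(/C=C/c1ccc(Nc2ccc(C(F)(F)F)cc2)cc1)CCC=C(C)C`, carries trifluoromethyl in place of methoxy on an aromatic carbon, and in this assay compound 3 gives > 36600 nM, also a limit. The steps a step that the two limits leave unreadable from compound 1 to compound 2 and a step that the two limits leave unreadable from compound 1 to compound 3 cannot be given a size because of the limit of > 36600 nM in this assay, at which 3 of the 3 values shown sit.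

Compound 4 has the structure `C=C[C@@](C)(/C=C/c1ccc(-c2cccc(F)c2)cc1)CCC=C(C)C`. It differs from compound 1 by 3-fluorophenyl in place of (4-methoxyphenyl)amino on an aromatic carbon. Among the measured compounds shown here, no measured step bears on this change, and the three limits give no direction of travel. The step that the limit leaves unreadable from compound 1 to compound 4 is therefore expected to stay unreadable, with compound 4 most likely ending at the same limit. Compound 4 is estimated to give 50000 nM, with a plausible range from 15000 nM to 200000 nM.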

Compound 4, half-maximal effective concentration: > 36600 nM
Compound 4 ended at the assay's limit; the forecaster's own chance of this, stated with the estimate: 80%; the middle value does not contradict the limit.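

Compound 4, like compound 1, gives only a limit of the assay, so the step between them cannot be read: the limit of > 36600 nM in this assay, at which 4 of the 4 values shown sit.

The compounds shown leave open how far any of them differ in this assay and which change to the shared core would give a readable value.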